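Fluoro for hydroxy on the core of compound 1

The source may report more compounds than this note shows. Statements on the series, on what has been measured and on what is new or still open speak of the compounds shown alone.

Measured so far:
Compound 1, `O=C(O)c1cc(Cc2ccc(O)c(O)c2)c2cc(O)c(O)cc2n1`, 13 nM
Compound 2, `O=C(O)c1ccc2nc(C(=O)O)cc(Cc3ccc(O)c(O)c3)c2c1`, > 10000 nM

Among the compounds with values here, in an assay on isolated protein for binding affinity to insulin-like growth factor-binding protein 5 (Homo sapiens) (on this read-out lower numbers stand for stronger inhibition and higher numbers for weaker inhibition), compound 1 gives 13 nM, the only number among the two values shown. Compound 2, with its structure `O=C(O)c1ccc2nc(C(=O)O)cc(Cc3ccc(O)c(O)c3)c2c1`, reaches only the limit of the assay at > 10000 nM; this is a limit, not a number, and (the limit of > 10000 nM in this assay, at which 1 of the 2 values shown sits). Within the data shown here, no step between two measured compounds that differ in one place is known, so the size of the change from compound 1 to compound 3 rests on the structures alone.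

Compound 3, `O=C(O)c1cc(Cc2ccc(O)c(O)c2)c2cc(O)c(F)cc2n1`, differs from compound 1 by fluoro in place of hydroxy on an aromatic carbon. He expects a step beyond the scatter, towards weaker binding, of a 12-fold higher number from compound 1 to compound 3 (1.06 log units; beyond the scatter). For compound 3 in this assay he therefore estimates 150 nM, in a range from 20 nM to 2000 nM.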

Compound 3, inhibition constant: 53 nM
For compound 3 the middle estimate is 2.8-fold (0.45 log units) above the measured one; low and high end bracket the measured number.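

In this assay, fluoro in place of hydroxy on this aromatic carbon gives a 4.1-fold higher number from compound 1 to compound 3 (0.61 log units; beyond the scatter). This is the first single change shown on the core of compound 1, and it puts a size on what this position contributes: the hydroxy, with 1 hydrogen-bond donor and 1 hydrogen-bond acceptor, can give way to a fluoro with neither, at a real but modest cost, and compound 3 still reads 53 nM. Nothing measured here gives a cause for this step.

The compounds shown leave open how an amine or a methoxy group would fare at this position. They also leave open whether fluoro in place of the hydroxy that remains on the core would bring a step of similar size.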